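Oxan-2-yl in place of trifluoromethyl on the isoindoline ring

The compounds below may be only part of what the source reports. "The series", "measured", "known", "first", "only" and "open" are said of these compounds alone.

Measured compounds:
compound 1, `C[C@H](Oc1ccc(S(C)(=O)=O)cc1C(=O)N1Cc2ccc(C(F)(F)F)cc2C1)C(F)(F)F`, 21 nM
compound 2, `C[C@H](Oc1ccc(S(C)(=O)=O)cc1C(=O)N1Cc2cnc(C(F)(F)F)cc2C1)C(F)(F)F`, 132 nM

In an assay on CHO cells for inhibition of sodium- and chloride-dependent glycine transporter 1 (Homo sapiens), read by scintillation counting (on this read-out higher numbers stand for an effect only at larger amounts of compound and lower numbers for an effect already at smaller amounts), compound 1 gives 21 nM, the lowest of the two numbers recorded. Compound 2, which gives 132 nM, sits at a higher number, and that gap lies beyond the scatter of repeated measurements. Going by the values given here, no pair of compounds that differ in exactly one place has been measured, so no single step has been quantified.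

Compound 3, `C[C@H](Oc1ccc(S(C)(=O)=O)cc1C(=O)N1Cc2ccc(C3CCCCO3)cc2C1)C(F)(F)F`, has not yet been measured. It differs from compound 1 by oxan-2-yl in place of trifluoromethyl on an aromatic carbon. The bicyclic part of the core keeps the same arrangement otherwise. Without a measured step of this kind to lean on, the expectation rests only on the value of compound 1, 21 nM, and the view that a change of this size is unlikely to leave the number unchanged. Compound 3 is expected to give 60 nM, within 20 nM to 200 nM, which would be a step of a 2.9-fold higher number from compound 1 to compound 3 (0.46 log units; beyond the scatter) toward a higher number, beyond the scatter, in this assay.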

Compound 3, half-maximal effective concentration: 205 nM
Compound 3: the middle estimate sits 3.4-fold (0.53 log units) below what was measured; measured number above the stated range.
By their numbers in this assay, from the lowest: compound 1; then compounds 2 and 3 (each within the scatter of the next).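

In this assay, going by these compounds alone, putting oxan-2-yl in place of trifluoromethyl on this aromatic carbon gives a 9.8-fold higher number from compound 1 to compound 3 (0.99 log units; beyond the scatter) and is the first single change measured at this place, so the read-out does depend on the group carried here. The change is not all-or-nothing: with a six-membered non-aromatic ring on this carbon, compound 3 still gives 205 nM in this assay. Nothing at hand explains why the number rises with this exchange.

With only this one replacement, the compounds shown leave open whether the rise follows from the ring of oxan-2-yl or from its oxygen, which a cyclohexyl group at the same carbon would separate. They also leave open how smaller groups, such as a nitrile or a methoxy group, would compare with trifluoromethyl here.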